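A few compounds are considered here, and "the series" means these few. Any claim that something is new, unique, unknown or untested is made for them only; others in the source may bear on it.

The measured compounds are:

compound 1, `O=C(COc1ccc(C(=O)/C=C/c2ccccc2Cl)cc1)N[C@H]1CCOC1=O`, which gives 4610 nM;
compound 2, `O=C(COc1ccc(C(=O)/C=C/c2cccc(F)c2)cc1)N[C@H]1CCOC1=O`, which gives 23200 nM;
compound 3, `O=C(COc1ccc(C(=O)/C=C/c2ccccc2)cc1)N[C@H]1CCOC1=O`, which gives 56800 nM.

All three were tested in a functional assay on PC-3 cells (Homo sapiens) for antiproliferative activity, read by MTT assay, with a stated time of 72 h; on this read-out lower numbers stand for stronger inhibition and higher numbers for weaker inhibition. Compound 3 stands at the highest number of the three. The step nearest to it is a 2.4-fold higher number from compound 2 to compound 3 (0.39 log units; beyond the scatter), and the furthest is a 12-fold higher number from compound 1 to compound 3 (1.09 log units; beyond the scatter); both steps go beyond the scatter, so compound 3 is the weakest of the three on this read-out.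

The unmeasured compound 4, `O=C(COc1ccc(C(=O)/C=C/c2ccc(F)c(F)c2)cc1)N[C@H]1CCOC1=O`, differs from compound 3 in one place: 3,4-difluorophenyl in place of phenyl on a double-bonded chain carbon bound to a double-bonded chain carbon. Two of the measured steps bear on this change. Each of them puts a halogen onto the ring in place of hydrogen and each lowers the number: a 2.4-fold higher number from compound 2 to compound 3 (0.39 log units; beyond the scatter) read in reverse, and a 12-fold higher number from compound 1 to compound 3 (1.09 log units; beyond the scatter) read in reverse. The third step, a 5.0-fold higher number from compound 1 to compound 2 (0.70 log units; beyond the scatter), shows that the two halogen patterns differ from each other by a modest amount. Since compound 4 carries two fluorines where compound 3 has none, a lower number than that of compound 3 is expected, beyond the scatter, and the step is estimated at a 4.1-fold lower number from compound 3 to compound 4 (0.61 log units; beyond the scatter). Compound 4 is therefore estimated at 14000 nM, with a range from 4500 nM to 42000 nM.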

Compound 4, half-maximal inhibitory concentration: 21900 nM
Beside the measured number, compound 4's estimate is 1.6-fold (0.19 log units) below it; the range from low to high includes it.
By their numbers in this assay, from the lowest: compound 1; then compounds 4 and 2 (each within the scatter of the next); then compound 3.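

In this assay, 3,4-difluorophenyl in place of phenyl on a double-bonded chain carbon bound to a double-bonded chain carbon gives a 2.6-fold lower number from compound 3 to compound 4 (0.41 log units; beyond the scatter) and so keeps the lowering already seen with the single halogens, but the step that adds fluoro in place of hydrogen to the 3-fluorophenyl ring gives a 1.1-fold lower number from compound 2 to compound 4 (0.03 log units; within the scatter) and so shows that this added fluoro brings no change that can be told from the scatter. Within the data shown here, the 2-chlorophenyl ring also keeps its lead over the new ring, with a 4.8-fold higher number from compound 1 to compound 4 (0.68 log units; beyond the scatter) on this read-out, so that carrying two fluoro groups at this position does not match the single chloro of the compound with the lowest number of the four. Nothing among the data gives a measured reason for any of these steps.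

Compound 1 and compound 2 differ in both the halogen and its place on the ring, so the compounds shown do not separate these two changes. They also leave open how the position responds to groups other than halogens, such as a methoxy group, an amine or a carboxylic acid on the ring.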